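Replacing 3-methyl-1H-1,2,4-triazol-5-yl with 1-methyl-1H-pyrazol-4-yl

The source may hold more compounds than are shown below. What is called first, only, known or untested is meant among the compounds shown, and "the series" means these compounds.

Three compounds share one core. In an in vitro functional assay on cells (Fibroblast) for agonist activity at Alpha-1A adrenergic receptor (Homo sapiens) (a higher number here means that more compound is needed for the effect, a lower number that less compound is needed), compound 1 `CCCCn1ncnc1-c1ccccc1NCC1=NCCN1` gives 200 nM, compound 2 `Cc1n[nH]c(-c2ccccc2NCC2=NCCN2)n1` gives 794 nM, and compound 3 `Cc1nc(-c2ccccc2NCC2=NCCN2)n(C)n1` gives 1000 nM. Compound 2 stands second highest of the three; its nearest neighbour is compound 3, with a 1.3-fold higher number from compound 2 to compound 3 (0.10 log units; within the scatter), while compound 1 gives a lower number than compound 2. Compound 4 `Cn1cc(-c2ccccc2NCC2=NCCN2)cn1` differs from compound 2 by 1-methyl-1H-pyrazol-4-yl in place of 3-methyl-1H-1,2,4-triazol-5-yl on an aromatic carbon. Among the measured compounds shown here, only the step from compound 2 to compound 3 touches this ring, and it stayed within the scatter; no measured step exchanges the ring itself. The step in this assay from compound 2 to compound 4 is therefore expected to be small, a 1.1-fold higher number from compound 2 to compound 4 (0.05 log units; within the scatter). Compound 4 is estimated at 900 nM, between 300 nM and 2700 nM.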

Compound 4, half-maximal effective concentration: 398 nM
Compound 4: middle estimate off by 2.3-fold (0.35 log units), on the high side; measured number inside the range.
By their numbers in this assay, from the lowest: compounds 1, 4, 2 and 3 (each within the scatter of the next, the first and the last beyond it).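

Exchanging 3-methyl-1H-1,2,4-triazol-5-yl for 1-methyl-1H-pyrazol-4-yl on this aromatic carbon gives, in this assay, a 2.0-fold lower number from compound 2 to compound 4 (0.30 log units; within the scatter). The ring itself, and not only a methyl on it, can therefore be exchanged here without a step beyond the scatter, with a ring of 2 hetero atoms standing in place of one with 3. No data shown give a reason for this outcome. The compounds shown leave open how a phenyl ring or an open-chain amine on this aromatic carbon would read.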